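Bromoacrylamide Series: Chloro for Methoxy on Two Cores

This account rests on a few compounds, and the source may have more. Where it says the series, first, only, none or still open, it means among the compounds named here.

Measured compounds:
compound 1 `C=C(Br)C(=O)Nc1cccc(-c2cn3c(-c4ccc(Cl)cc4)csc3n2)c1` 1100 nM
compound 2 `C=C(Br)C(=O)Nc1cccc(-c2cn3c(-c4ccc(OC)cc4)csc3n2)c1` 620 nM
compound 3 `C=C(Br)C(=O)Nc1cccc(-c2cn3nc(-c4ccc(OC)cc4)sc3n2)c1` 890 nM

In a functional assay on FM3A cells (Mus musculus) for inhibition, read by cell counting, with a stated time of 2 days (a lower number here means a stronger inhibitor, a higher number a weaker inhibitor), compound 2 gives 620 nM, and compound 1 gives 1100 nM. The change between them is chloro in place of methoxy on an aromatic carbon, and it made a step of a 1.8-fold higher number from compound 2 to compound 1 (0.25 log units; within the scatter). Compound 3, built on a different core, gives 890 nM; the difference between the two cores is not broken down here, and the values of compound 2 and compound 3 lie within the scatter of each other.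

Compound 4 `C=C(Br)C(=O)Nc1cccc(-c2cn3nc(-c4ccc(Cl)cc4)sc3n2)c1` is not yet measured. It differs from compound 3 by chloro in place of methoxy on an aromatic carbon, the same change as that from compound 2 to compound 1, at a place described in the same words. The step from compound 3 to compound 4 is expected to be a 1.7-fold higher number from compound 3 to compound 4 (0.23 log units; within the scatter), resting on the earlier step of a 1.8-fold higher number from compound 2 to compound 1 (0.25 log units; within the scatter). Compound 4 is therefore estimated at 1500 nM, with a range from 700 nM to 3500 nM.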

Compound 4, half-maximal inhibitory concentration: 2000 nM
Beside the measured number, compound 4's estimate is 1.3-fold (0.12 log units) below it; measured number inside the range.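

In this assay, chloro in place of methoxy on the core of compound 3 gave a 2.2-fold higher number from compound 3 to compound 4 (0.35 log units; beyond the scatter), so the number rose on both cores. The two steps cannot be told apart: the same change on two cores in this assay, a 1.8-fold higher number (0.25 log units; within the scatter) from compound 2 to compound 1 and a 2.2-fold higher number (0.35 log units; beyond the scatter) from compound 3 to compound 4, 1.3-fold (0.10 log units) apart, within the scatter of two such steps. Within the data shown here, with only one pair on each core, this shows that the change from 4-methoxyphenyl to 4-chlorophenyl carried over between these two cores in this assay, but not that it would carry to any other core or that the two steps are truly equal.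

The compounds shown leave open whether a methyl, a fluoro or an amine at the same place would behave alike on both cores. They also leave open what happens when a plain acetamide replaces the bromoacrylamide.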